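The compounds below may be only part of what the source reports. "The series", "measured", "known", "first", "only" and "open" are said of these compounds alone.

Measured so far:
- compound 1, `CCOC(=O)C1=C(C)NC(C)=C(C(=O)OCC)C1c1ccc(OCC(=O)Nc2nc3ccccc3s2)cc1`: 47.7%
- compound 2, `CCOC(=O)C1=C(C)NC(C)=C(C(=O)OCC)C1c1ccc(OCC(=O)NNC(=O)c2sccc2Cl)cc1`: 10.6%
- compound 3, `CCOC(=O)C1=C(C)NC(C)=C(C(=O)OCC)C1c1ccc(OCC(=O)NNC(=O)c2cccs2)cc1`: 44%

All three share one core and differ only in the group attached to the amide-type nitrogen of the side chain. In a functional assay on the whole organism (strain Wistar) for inhibition, with Rattus norvegicus as the target, read by paw edema, with stated times of 30 min and 0.5 h, at a dose of 20 mg/kg (on this read-out higher numbers stand for more inhibition at the one dose given (going by the name of the read-out) and lower numbers for less inhibition), compound 3 gives 44%, the second highest of the three numbers; compound 1, with 47.7%, sits within the scatter of it, while compound 2, with 10.6%, sits far below it. The two steps into compound 3 show this: a number 3.7 percentage points lower from compound 1 to compound 3 (within the scatter), and a number 33.4 percentage points higher from compound 2 to compound 3 (beyond the scatter).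

Compound 4, `CCOC(=O)C1=C(C)NC(C)=C(C(=O)OCC)C1c1ccc(OCC(=O)NNC(=O)CCC(=O)O)cc1`, has not been measured. Its change from compound 3 is 2-carboxyethyl in place of thiophen-2-yl on a carbonyl carbon. Among the measured compounds shown here, no measured step swaps the ring for an open chain, so the earlier steps bear on this one only loosely: the large step from compound 2 to compound 3 shows that the group on this carbonyl can move the number a great deal, while the step from compound 1 to compound 3 shows it can also leave it unchanged. A modest drop is expected, with wide uncertainty: a number 12 percentage points lower from compound 3 to compound 4 (beyond the scatter). Compound 4 is estimated at 32%, within 10% to 50%.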

Compound 4, a percentage reported as inhibition, in the whole organism at one dose (the size of the read-out at that dose, not a potency): 34.9%
The estimate for compound 4 lay 2.9 percentage points below the measured number; low and high end bracket the measured number.
By their numbers in this assay, from the lowest: compound 2; then compounds 4, 3 and 1 (each within the scatter of the next, the first and the last beyond it).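

In this assay, the open 2-carboxyethyl chain can stand on this carbonyl carbon in place of the thiophen-2-yl ring with a number 9.1 percentage points lower from compound 3 to compound 4 (within the scatter) and the number holds, so for this pair the ring is not required. Set against the 3-chlorothiophen-2-yl group, the same chain gives a number 24.3 percentage points higher from compound 2 to compound 4 (beyond the scatter) and so does not share the low number of that chlorinated ring. Set against the 1,3-benzothiazol-2-yl group, the ((2-carboxyethyl)carbonyl)amino group gives a number 12.8 percentage points lower from compound 1 to compound 4 (beyond the scatter) and this separates two groups that the ring-bearing compound 3 did not separate.

The compounds shown leave open whether a longer chain ending in a carboxylic acid, or a chain ending in an amine, would hold the number at this position. Nothing available here explains why these groups give these numbers.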